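Swapping a hydroxylated benzyl chain for a fluorobenzoyl cap

The compounds below may be only part of what the source reports. "The series", "measured", "known", "first", "only" and "open" are said of these compounds alone.

Three compounds share a core in which a piperidine-like ring carries an amine linked through a short chain and a sulfur to a bis(fluorophenyl)methyl group. Compound 1 `OC(Cc1ccccc1)CN1CCC(NCCSC(c2ccc(F)cc2)c2ccc(F)cc2)CC1` gives 31.4 nM in an assay on membranes from striatum (strain Sprague-Dawley) for displacement of a labelled ligand from sodium-dependent dopamine transporter (Rattus norvegicus), read by scintillation counting, with a stated time of 120 min (on this read-out higher numbers stand for weaker inhibition and lower numbers for stronger inhibition), and so has the lowest number of the three. Compound 2 `O=C(c1ccc(F)cc1)N1CCC(NCC[S+]([O-])C(c2ccc(F)cc2)c2ccc(F)cc2)CC1`, which carries a (4-fluorophenyl)carbonyl on the ring nitrogen and an oxidised sulfur, gives 77.2 nM, and compound 3 `CC(C)(C)CN1CCC(NCC[S+]([O-])C(c2ccc(F)cc2)c2ccc(F)cc2)CC1`, with neopentyl in that place, gives 431 nM.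

Compound 4 `O=C(c1ccccc1F)N1CCC(NCCSC(c2ccc(F)cc2)c2ccc(F)cc2)CC1` is the unmeasured analogue of compound 1 with the change ((2-fluorophenyl)carbonyl in place of 2-hydroxy-3-phenylpropyl on an amine nitrogen in a ring). Going by the values given here, the only directly comparable step is a 5.6-fold higher number from compound 2 to compound 3 (0.75 log units; beyond the scatter), which shows that an aryl carbonyl on the ring nitrogen does better than a simple alkyl group. Compound 1 already has the lowest number, so the expectation is that the change in compound 4 moves it little: a step of a 1.1-fold higher number from compound 1 to compound 4 (0.05 log units; within the scatter) within or near the scatter is estimated. Compound 4 is therefore expected to give about 35 nM, with a plausible range from 12 nM to 110 nM.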

Compound 4, inhibition constant: 46.1 nM
Compound 4: the middle estimate sits 1.3-fold (0.12 log units) below what was measured, and the stated range covers the measured number.
By their numbers in this assay, from the lowest: compounds 1, 4 and 2 (each within the scatter of the next, the first and the last beyond it); then compound 3.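

At the amine nitrogen in the ring, with the sulfur not oxidised, the result gives a 1.5-fold higher number from compound 1 to compound 4 (0.17 log units; within the scatter) in this assay, so the two compounds cannot be told apart on this read-out. The earlier step at this place involved only oxidised-sulfur compounds, whereas this one shows that 2-hydroxy-3-phenylpropyl, with its hydrogen-bond donor, and (2-fluorophenyl)carbonyl, with none, fall within the scatter of each other on the core of compound 1. No supporting data bear on why these two different groups give such similar numbers.

The compounds shown leave open how a plain benzoyl group, without the fluorine, or a carboxylic acid on the group at this nitrogen would read. Going by these compounds alone, they also include no pair that differs only in the oxidation of the sulfur, so that change cannot be judged separately.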